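Swapping Benzyl for Phenyl on a Thiourea Nitrogen

The source may report more compounds than this note shows. Statements on the series, on what has been measured and on what is new or still open speak of the compounds shown alone.

The measured compounds:
compound 1, `CC(C)C[C@H](NC(=S)NCc1ccccc1)c1nc2ccccc2[nH]1`, gives 21100 nM in a functional assay on DU-145 cells (Homo sapiens) for cytotoxicity, read by MTT assay; a lower number here means a stronger inhibitor, a higher number a weaker inhibitor;
compound 2, `CC(C)[C@@H](NC(=S)NCc1ccccc1)c1nc2ccccc2[nH]1`, gives 17300 nM in this assay;
compound 3, `CC(C)C[C@H](NC(=S)Nc1ccccc1)c1nc2ccccc2[nH]1`, gives 28900 nM in this assay.

All three values lie within the usual scatter of one another, so none of them can be called stronger or weaker than the rest. Compound 1 and compound 3 differ in one place only: phenyl in place of benzyl on an amide-type nitrogen. This change produced a 1.4-fold higher number from compound 1 to compound 3 (0.14 log units; within the scatter), a step that does not rise above the noise of repeated measurement.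

Compound 2 shares the thiourea and the benzyl group of compound 1 but carries a different core; how the two cores differ is not broken down here.

Compound 4, `CC(C)[C@@H](NC(=S)Nc1ccccc1)c1nc2ccccc2[nH]1`, has not yet been measured. It stands to compound 2 exactly as compound 3 stands to compound 1: phenyl in place of benzyl on an amide-type nitrogen. The place of the change is the same in both pairs, an amide-type nitrogen whose other neighbour is the thiocarbonyl carbon, so this is the same change made on a second core.

Because a 1.4-fold higher number from compound 1 to compound 3 (0.14 log units; within the scatter) was small, the expectation for compound 4 is a similarly small step, a 1.4-fold higher number from compound 2 to compound 4 (0.14 log units; within the scatter). On that basis compound 4 is estimated at 24000 nM in this assay, with a likely range from 12000 nM to 50000 nM.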

Compound 4, half-maximal inhibitory concentration: 34800 nM
Compound 4: middle estimate off by 1.5-fold (0.16 log units), on the low side; low and high end bracket the measured number.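

On the second core, phenyl in place of benzyl on an amide-type nitrogen gives a 2.0-fold higher number from compound 2 to compound 4 (0.30 log units; within the scatter) in this assay. Set beside the step on the first core, the two results agree as far as these measurements can tell: the same change on two cores in this assay, a 1.4-fold higher number (0.14 log units; within the scatter) from compound 1 to compound 3 and a 2.0-fold higher number (0.30 log units; within the scatter) from compound 2 to compound 4, 1.5-fold (0.17 log units) apart, within the scatter of two such steps. This shows that the swap carries from one core to the other without a readable difference, as neither step rises above the noise of repeated measurement, but it does not show that either group is better than the other, and two pairs of compounds give no rule for any further core.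

The compounds shown leave open whether a different group on this nitrogen, such as a longer chain like phenylethyl, a saturated ring like cyclohexyl, or a phenyl ring carrying an amine or a carboxylic acid, would move the number beyond the scatter. They also leave open whether the same swap would behave alike with a carbonyl in place of the thiocarbonyl, or on a core with a different side chain from the two seen here.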